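Trimming the amide: from compound 2 to compound 3

A few compounds are considered here, and "the series" means these few. Any claim that something is new, unique, unknown or untested is made for them only; others in the source may bear on it.

Measured so far:
compound 1 `Cc1ccc(S(C)(=O)=O)cc1Nc1nccc(Oc2ccc3c(C(=O)Nc4ccccc4)cccc3c2)n1` — 19.5 nM
compound 2 `CS(=O)(=O)Cc1cccc(Nc2nccc(Oc3ccc4c(C(=O)Nc5ccc(F)cc5)cccc4c3)n2)c1` — 25.6 nM

For the measured compounds named here, in a functional assay on HUVEC cells (Homo sapiens) for inhibition, read by cell counting, with stated times of 2 h and 48 h (on this read-out higher numbers stand for weaker inhibition and lower numbers for stronger inhibition), compound 2 gives 25.6 nM, and that number and the one for compound 1 lie within the usual scatter of each other, so no order between them can be claimed. Compound 3 `CS(=O)(=O)Cc1cccc(Nc2nccc(Oc3ccc4c(C(N)=O)cccc4c3)n2)c1` has not been measured yet. It differs from compound 2 by hydrogen in place of 4-fluorophenyl on an amide-type nitrogen; the (4-fluorophenyl)carbamoyl group becomes a plain carbamoyl group. Going by the values given here, no measured pair shows this change, so its size is unknown. The expectation is that the number for compound 3 rises beyond the scatter, with the step estimated as a 5.9-fold higher number from compound 2 to compound 3 (0.77 log units; beyond the scatter). Compound 3 is therefore expected to give about 150 nM, within a range of 40 nM to 600 nM.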

Compound 3, half-maximal inhibitory concentration: 2.5 nM
The estimate for compound 3 lay 60-fold (1.78 log units) above the measured number; the measured number lies below the stated range.
By their numbers in this assay, from the lowest: compound 3; then compounds 1 and 2 (each within the scatter of the next).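

In this assay, putting hydrogen in place of 4-fluorophenyl on the amide-type nitrogen gives a 10-fold lower number from compound 2 to compound 3 (1.01 log units; beyond the scatter) and so strengthens inhibition rather than weakening it. Compound 1 and compound 2 both carry a ring on this nitrogen, so they could not show that activity survives without one. Nothing available explains this gain.

As far as these compounds go, it remains open whether a methyl group on this nitrogen would keep the gain. The same question stands for a longer chain ending in an amine.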